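Extending a Side Chain on a Weak Series

The compounds below may be only part of what the source reports. "The series", "measured", "known", "first", "only" and "open" are said of these compounds alone.

The measurements so far, all in a functional assay, with a stated time of 30 min; a lower number here means that less compound is needed, a higher number that more compound is needed for the effect:

Compound 1, `CC(C)=NNc1nc(-c2cccc([N+](=O)[O-])c2)cs1`, gives 510000 nM.
Compound 2, `CCC/C(C)=N\Nc1nc(-c2cccc([N+](=O)[O-])c2)cs1`, gives 550000 nM.
Compound 3, `CCC/C(CC)=N\Nc1nc(-c2cccc([N+](=O)[O-])c2)cs1`, gives 530000 nM.

All three compounds sit close together, and the steps between them show it: a 1.1-fold higher number from compound 1 to compound 2 (0.03 log units; within the scatter), a 1.0-fold lower number from compound 2 to compound 3 (0.02 log units; within the scatter) and a 1.0-fold higher number from compound 1 to compound 3 (0.02 log units; within the scatter). The change from compound 1 to compound 2 is ethyl in place of hydrogen on a saturated chain carbon bound to a carbon with a double bond to nitrogen; it made a step of a 1.1-fold higher number from compound 1 to compound 2 (0.03 log units; within the scatter).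

Compound 4, `CCCCC/C(CC)=N\Nc1nc(-c2cccc([N+](=O)[O-])c2)cs1`, has not yet been measured. It differs from compound 3 by ethyl in place of hydrogen on a saturated chain carbon, three bonds along the chain from a carbon with a double bond to nitrogen. Going by the values given here, this is the same kind of change as the one from compound 1 to compound 2, but not the same: in the earlier case the new ethyl sits on a saturated chain carbon bound to a carbon with a double bond to nitrogen, whereas in compound 4 it sits on a saturated chain carbon, three bonds along the chain from a carbon with a double bond to nitrogen. The two starting points also differ: compound 3 differs from compound 1 by a group of 7 heavy atoms (6 carbon, 1 nitrogen; no ring) in place of a group of 4 heavy atoms (3 carbon, 1 nitrogen; no ring), on a nitrogen on an aromatic ring.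

Because a 1.1-fold higher number from compound 1 to compound 2 (0.03 log units; within the scatter) stayed within the scatter, and because a 1.0-fold lower number from compound 2 to compound 3 (0.02 log units; within the scatter) did too, the expected step from compound 3 to compound 4 is also small, a 1.1-fold higher number from compound 3 to compound 4 (0.02 log units; within the scatter). Compound 4 is therefore estimated at 560000 nM, expected to fall between 280000 nM and 1100000 nM.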

Compound 4, half-maximal effective concentration: 590000 nM
Beside the measured number, compound 4's estimate is 1.1-fold (0.02 log units) below it; measured number inside the range.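

In this assay, ethyl in place of hydrogen on a saturated chain carbon, three bonds along the chain from a carbon with a double bond to nitrogen, gives a 1.1-fold higher number from compound 3 to compound 4 (0.05 log units; within the scatter), so this step is too small to count as a real difference. Set beside the earlier step, the change reads the same on the two cores, even though the new ethyl does not sit in the same place in each: the same change on two cores in this assay, a 1.1-fold higher number (0.03 log units; within the scatter) from compound 1 to compound 2 and a 1.1-fold higher number (0.05 log units; within the scatter) from compound 3 to compound 4, 1.0-fold (0.01 log units) apart, within the scatter of two such steps. Going by these compounds alone, this shows only that the change left the number within the scatter in both cases; with no step of real size to compare, it does not show that an effect of this change would carry from one core to another, and two cases cannot establish a rule for the whole series.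

Within the data shown here, whether an amine or a carboxylic acid on the chain, or a chain longer than the one in compound 4, would give a step beyond the scatter remains open. The four compounds shown differ only in the chain, so they say nothing about changes elsewhere in the molecule.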